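Notes on the step from compound 3 to compound 4

The source may hold more compounds than are shown below. What is called first, only, known or untested is meant among the compounds shown, and "the series" means these compounds.

Compound 3 `CN(C[C@H]1Cc2c(cccc2N2CCNCC2)CN1)[C@H]1CCCc2cccnc21` stands highest of the three measured compounds in an ADME assay on microsomes from liver (Homo sapiens) for metabolic stability, read by LC-MS, with a stated time of 10 min (a higher number here means that more of the compound is left, a lower number that less of the compound is left), where compound 3 gives 99.7%. Compound 1 `Cc1cnc2c(c1)CCC[C@@H]2N(C)C[C@H]1Cc2c(cccc2N2CCNCC2)CN1` gives 47.8% and compound 2 `c1cnc2c(c1)CCC[C@@H]2N(CC1CCCCC1)C[C@H]1Cc2c(cccc2N2CCNCC2)CN1` gives 81.6%; the steps of a number 51.9 percentage points higher from compound 1 to compound 3 (beyond the scatter) and a number 18.1 percentage points higher from compound 2 to compound 3 (beyond the scatter) both lie beyond the scatter. Compound 4 `CN(C[C@H]1Cc2c(cccc2N2CCN(c3ccccn3)CC2)CN1)[C@H]1CCCc2cccnc21` differs from compound 3 by pyridin-2-yl in place of hydrogen on an amine nitrogen in a ring. For the measured compounds named here, neither measured step touches the amine nitrogen in a ring, so neither bears directly on this change; they show only that changes elsewhere in the shared core moved the read-out by large and modest amounts. Compound 3 sits close to the top of the scale, so no upward step beyond the scatter is possible, and the expected step is a number 14.7 percentage points lower from compound 3 to compound 4 (beyond the scatter), with wide uncertainty. Compound 4 is estimated at 85%, between 55% and 100%.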

Compound 4, percent of the compound remaining: 27.4%
Compound 4: middle estimate off by 57.6 percentage points, on the high side, and the stated range ends above it.
By their numbers in this assay, from the lowest: compound 4; then compound 1; then compound 2; then compound 3.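

In this assay the amine nitrogen in a ring proves highly sensitive to substitution: pyridin-2-yl in place of hydrogen gives a number 72.3 percentage points lower from compound 3 to compound 4 (beyond the scatter) and is the largest step among those read so far. For the compounds shown here, this is the first reading at this position, and it shows that the free ring nitrogen of compound 3 cannot be replaced by this aromatic ring without a heavy loss in this read-out. No measurement at hand accounts for the step. On these data alone, whether the loss belongs to pyridin-2-yl alone or to any group on this nitrogen stays open. A methyl, an acetyl or a phenyl at the same place would separate these cases.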